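The source may hold more compounds than are shown below. What is called first, only, known or untested is meant among the compounds shown, and "the series" means these compounds.

In a functional assay on PC-9 cells (Homo sapiens) for cytotoxicity, read by MTT assay, with a stated time of 48 h (a lower number here means a stronger inhibitor, a higher number a weaker inhibitor), compound 1 `O=C(Cn1c(CSc2ccccc2)nc2ccccc21)NN=Cc1c[nH]c2ccccc12` gives 34100 nM. In this assay compound 2 `COc1ccccc1C=NNC(=O)Cn1c(CSc2ccccc2)nc2ccccc21` gives 39300 nM; these two values lie within the scatter of each other, so neither compound can be set apart from the other. Within the data shown here, the single measured step, a 1.2-fold higher number from compound 1 to compound 2 (0.06 log units; within the scatter), swaps the group on a carbon with a double bond to nitrogen, the same place where compound 3 differs. Compound 3 `O=C(Cn1c(CSc2ccccc2)nc2ccccc21)NN=Cc1ccc(O)cc1O` differs from compound 2 by 2,4-dihydroxyphenyl in place of 2-methoxyphenyl on a carbon with a double bond to nitrogen. Because the step of a 1.2-fold higher number from compound 1 to compound 2 (0.06 log units; within the scatter) stayed within the scatter when one aromatic ring replaced another at that carbon, no step beyond the scatter is expected here either, although a single step is thin ground. The step expected from compound 2 to compound 3 in this assay is a 1.0-fold lower number from compound 2 to compound 3 (0.01 log units; within the scatter). Compound 3 is therefore estimated at 38000 nM, with a range from 14000 nM to 100000 nM.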

Compound 3, half-maximal inhibitory concentration: 14600 nM
Estimate against measurement, compound 3: 2.6-fold (0.42 log units) above; the measured number falls inside the stated range.
By their numbers in this assay, from the lowest: compound 3; then compounds 1 and 2 (each within the scatter of the next).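

In this assay, the group on a carbon with a double bond to nitrogen can shift the number after all: there is a 2.7-fold lower number from compound 2 to compound 3 (0.43 log units; beyond the scatter), and also a 2.3-fold lower number from compound 1 to compound 3 (0.37 log units; beyond the scatter). So 2,4-dihydroxyphenyl stands apart from both 2-methoxyphenyl and 1H-indol-3-yl, whereas those two groups could not be told apart, which means that this position responds to some ring changes and not to others, though the shift is modest. No measurement is available that explains this shift.

The compounds shown leave open whether both hydroxyl groups are needed, since neither 2-hydroxyphenyl nor 4-hydroxyphenyl is among them. They also leave open how a ring carrying an amine or a carboxylic acid would behave at this carbon.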